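A few compounds are considered here, and "the series" means these few. Any claim that something is new, unique, unknown or untested is made for them only; others in the source may bear on it.

Compounds measured so far:
- compound 1, `O=C(Nc1ccc(F)cc1)N1CCc2ccccc2[C@H]1c1ccc(C(F)(F)F)cc1`: 36 nM
- compound 2, `N#Cc1ccccc1NC(=O)N1CCc2ccccc2[C@H]1c1ccc(C(F)(F)F)cc1`: 424 nM
- compound 3, `O=C(Nc1ccncc1)N1CCc2ccccc2[C@H]1c1ccc(C(F)(F)F)cc1`: 398 nM

All three share one core and differ only in the group on the urea nitrogen. In an assay on isolated protein for antagonist activity at transient receptor potential cation channel subfamily M member 8 (Homo sapiens), read by luminescence and calcium flux, with a stated time of 2.5 min (on this read-out higher numbers stand for weaker inhibition and lower numbers for stronger inhibition), compound 1 gives the lowest of the three numbers. The nearest to it is compound 3, and the gap is an 11-fold higher number from compound 1 to compound 3 (1.04 log units; beyond the scatter). The step to compound 2 is of the same size, a 12-fold higher number from compound 1 to compound 2 (1.07 log units; beyond the scatter), so both replacements of the 4-fluorophenyl weakened inhibition clearly. Between compound 2 and compound 3 the difference is a 1.1-fold lower number from compound 2 to compound 3 (0.03 log units; within the scatter), which cannot be told apart from repeat scatter.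

Compound 4, `CC(C)NC(=O)N1CCc2ccccc2[C@H]1c1ccc(C(F)(F)F)cc1`, has not yet been measured. It differs from compound 1 by isopropyl in place of 4-fluorophenyl on an amide-type nitrogen. Among the measured compounds shown here, no measured step covers an alkyl group at this position; the two steps that bear on it, both from compound 1, show that each change made there so far weakened inhibition clearly in this assay. On that basis compound 4 is expected to fall back from compound 1 by a step of roughly a 9.7-fold higher number from compound 1 to compound 4 (0.99 log units; beyond the scatter), giving an estimated value of 350 nM for compound 4, with a likely range of 90 nM to 1500 nM.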

Compound 4, half-maximal inhibitory concentration: 44 nM
The estimate for compound 4 lay 8.0-fold (0.90 log units) above the measured number; measured number below the stated range.
By their numbers in this assay, from the lowest: compounds 1 and 4 (each within the scatter of the next); then compounds 3 and 2 (each within the scatter of the next).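

In this assay, the aromatic ring of the 4-fluorophenyl group proves dispensable at this position, since replacing it with isopropyl, which has no ring and fewer heavy atoms, gives a step that stays within the scatter (a 1.2-fold higher number from compound 1 to compound 4 (0.09 log units; within the scatter)). The two earlier losses therefore do not hold for every replacement of 4-fluorophenyl on this amide-type nitrogen, because isopropyl stands clearly apart from both pyridin-4-yl (a 9.0-fold lower number from compound 3 to compound 4 (0.96 log units; beyond the scatter)) and 2-cyanophenyl (a 9.6-fold lower number from compound 2 to compound 4 (0.98 log units; beyond the scatter)), so the identity of the entering group matters and the mere presence of a ring does not decide the outcome. Nothing measured here explains why these groups behave so differently.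

The compounds shown leave open whether isopropyl is a special case or whether other alkyl groups, such as methyl, a longer chain like n-butyl or a cyclohexyl ring, would also give numbers in the range of compound 1 and compound 4. They also leave open how far this position tolerates an amine or a carboxylic acid carried on such a chain, and whether plain phenyl would match 4-fluorophenyl.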